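The source may hold more compounds than are shown below. What is called first, only, known or untested is meant among the compounds shown, and "the series" means these compounds.

Among the measured compounds shown here, compound 2 `COc1ccc([C@@H]2CC(=O)c3c(O)cc(OCc4cn(Cc5cccc(C#N)c5)nn4)cc3O2)cc1O` stands at the top of the two numbers measured so far: in a functional assay on RAW264.7 cells (Mus musculus) for inhibition, read by Griess assay, with stated times of 2 h and 24 h (a lower number here means a stronger inhibitor, a higher number a weaker inhibitor), compound 2 gives 18000 nM. For the measured compounds named here, its only neighbour is compound 1 `COc1ccc([C@@H]2CC(=O)c3c(O)cc(OCc4cn(C5CCCC5)nn4)cc3O2)cc1O`, which in this assay gives 10500 nM. The step of a 1.7-fold higher number from compound 1 to compound 2 (0.23 log units; within the scatter) is within the scatter, so no order between compound 1 and compound 2 is claimed; both sit in the same weak range.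

Compound 3 `COc1ccc([C@@H]2CC(=O)c3c(O)cc(OCc4cn(Cc5ccc(Cl)cc5)nn4)cc3O2)cc1O` is the next member of the series. Against compound 2 the change is 4-chlorophenyl in place of 3-cyanophenyl on a saturated chain carbon bound to an aromatic nitrogen; the rest of the molecule is unchanged. Going by the values given here, the one measured step, a 1.7-fold higher number from compound 1 to compound 2 (0.23 log units; within the scatter), exchanges cyclopentyl for a benzyl group on the aromatic nitrogen and was within the scatter; no measured pair yet compares two differently substituted benzyl groups at this place, so the new change has no direct precedent. Among the compounds with values here, with the only known step at this position flat, the expected step for compound 3 is a 1.2-fold lower number from compound 2 to compound 3 (0.08 log units; within the scatter), none beyond the scatter. Compound 3 is therefore estimated at 15000 nM in this assay, with a range from 5000 nM to 45000 nM.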

Compound 3, half-maximal inhibitory concentration: 17800 nM
Estimate against measurement, compound 3: 1.2-fold (0.07 log units) below; the measured number falls inside the stated range.
By their numbers in this assay, from the lowest: compounds 1, 3 and 2 (each within the scatter of the next).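

In this assay, among the compounds shown here, the first pair of differently substituted benzyl groups on the aromatic nitrogen gives a 1.0-fold lower number from compound 2 to compound 3 (0.00 log units; within the scatter), so the numbers for 3-cyanobenzyl and 4-chlorobenzyl cannot be told apart, even though the nitrile and its hydrogen-bond acceptor are gone from compound 3. The second comparison with cyclopentyl, a 1.7-fold higher number from compound 1 to compound 3 (0.23 log units; within the scatter), is also within the scatter, so the three groups on this nitrogen, one saturated ring and two substituted benzyl groups, all sit in the same weak range and show no order among them. Nothing available on these compounds offers an explanation for this flat result.

Because 3-cyanobenzyl and 4-chlorobenzyl differ in both the substituent and its place on the ring, these compounds cannot separate the two, and a pair such as 4-cyanobenzyl against 4-chlorobenzyl would be needed to do so. As far as these compounds go, it also remains open whether the flat range extends to groups of another kind on this nitrogen, such as a benzyl group carrying a carboxylic acid or an amine, or a longer alkyl chain.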